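Trimming the Ethoxy of Compound 2 Down to Methyl

A few compounds are considered here, and "the series" means these few. Any claim that something is new, unique, unknown or untested is made for them only; others in the source may bear on it.

Going by the values given here, compound 2 `CCOc1cccc(S(=O)(=O)Nc2ccc(N3CCN(c4cccc(-c5c(C(=O)NCCCN6CCN(C)CC6)c(C)n(C)c5-c5ccc(Cl)cc5)c4)CC3)cc2)c1` has the lower of the two numbers measured so far in an assay for inhibition of Apoptosis regulator Bcl-2 (Homo sapiens), read by fluorescence polarization, with a stated time of 2 h (on this read-out higher numbers stand for weaker inhibition and lower numbers for stronger inhibition), where compound 2 gives 1620 nM. Among the compounds with values here, its only neighbour, compound 1 `Cc1c(C(=O)NCCCN2CCN(C)CC2)c(-c2cccc(N3CCN(c4ccc(NS(=O)(=O)c5cccc(OC(C)C)c5)cc4)CC3)c2)c(-c2ccc(Cl)cc2)n1C`, gives 2020 nM in this assay, and the step of a 1.2-fold lower number from compound 1 to compound 2 (0.10 log units; within the scatter) shows the two cannot be told apart. Compound 3 `Cc1cccc(S(=O)(=O)Nc2ccc(N3CCN(c4cccc(-c5c(C(=O)NCCCN6CCN(C)CC6)c(C)n(C)c5-c5ccc(Cl)cc5)c4)CC3)cc2)c1` differs from compound 2 by methyl in place of ethoxy on an aromatic carbon. Within the data shown here, the only measured step that bears on this, the change from compound 1 to compound 2, also alters the alkoxy group on that aromatic ring, and it was a 1.2-fold lower number from compound 1 to compound 2 (0.10 log units; within the scatter). Since that earlier shortening of the alkoxy group moved the number only within the scatter, the step to compound 3 is expected to be small as well, a 1.2-fold higher number from compound 2 to compound 3 (0.07 log units; within the scatter), with no clear direction. Compound 3 is therefore estimated at 1900 nM in this assay, with a range from 700 nM to 5000 nM.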

Compound 3, half-maximal inhibitory concentration: 689 nM
For compound 3 the middle estimate is 2.8-fold (0.44 log units) above the measured one; the whole stated range lies above it.
By their numbers in this assay, from the lowest: compound 3; then compounds 2 and 1 (each within the scatter of the next).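

In this assay, swapping one alkoxy group for another at this place on the ring had left the number within the scatter, but replacing the alkoxy group with methyl moves it beyond the scatter: ethoxy to methyl gives a 2.4-fold lower number from compound 2 to compound 3 (0.37 log units; beyond the scatter), and isopropoxy to methyl gives a 2.9-fold lower number from compound 1 to compound 3 (0.47 log units; beyond the scatter). The position is therefore not indifferent to what it carries: compound 1 and compound 2 remain within the scatter of each other, while compound 3 stands apart from both. Nothing among the data shown accounts for why methyl goes with the lower number here.

The compounds shown leave open whether the oxygen or the length of the group is what counts, and a methoxy group at the same place would bear on that. From the compounds shown here alone, how hydrogen, chlorine or an amine would fare on this aromatic carbon also remains open.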